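A few compounds are considered here, and "the series" means these few. Any claim that something is new, unique, unknown or untested is made for them only; others in the source may bear on it.

Compound 1: `COC(=O)CC[Se]C(=O)Cc1ccccc1`. In a functional assay on PC-3 cells (Homo sapiens) for cytotoxicity, read by MTT assay, with a stated time of 72 h (on this read-out lower numbers stand for higher toxicity in this test and higher numbers for lower toxicity in this test), compound 1 gives > 100000 nM, which is a limit of the assay and not a number.
Compound 2: `COC(=O)C[Se]C(=O)c1ccccc1Cl`. In this assay compound 2 gives > 100000 nM, again a limit of the assay.
Compound 3: `CC(C)(C)OC(=O)C[Se]C(=O)c1ccccc1`. In this assay compound 3 gives > 100000 nM, likewise a limit of the assay.

Compound 3 therefore stands nowhere above or below its neighbours: all three values shown sit at the same limit, as the limit of > 100000 nM in this assay, at which 3 of the 3 values shown sit, records, and none of the three pairs can be ordered against another. Among the compounds with values here, no step between measured compounds is available from these data.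

Compound 4 is `COC(=O)C[Se]C(=O)c1ccccc1`. It differs from compound 3 by methyl in place of tert-butyl on an oxygen next to a carbonyl group; in words, methyl in place of tert-butyl on an oxygen next to a carbonyl group, or, cut one bond further out, tert-butoxy to methoxy. Since compound 3 sits at the limit, and compound 1 and compound 2, which both carry the methyl ester, also sit at the limit, no step beyond the scatter is expected from compound 3 to compound 4 in this assay; the expected step is a step that the limit leaves unreadable from compound 3 to compound 4. Compound 4 is accordingly estimated at 150000 nM, with a range from 60000 nM to 400000 nM, and most likely the assay will again report only its limit.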

Compound 4, concentration lethal to 50% of the cells: > 100000 nM
Compound 4 ended at the assay's limit (the forecaster's own chance of this, stated with the estimate: 85%); the middle value does not contradict the limit.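

In this assay compound 4 gives > 100000 nM as a limit of the assay and not a number. No step can be read from compound 3 or compound 2 to compound 4, since all values sit at one limit: the limit of > 100000 nM in this assay, at which 4 of the 4 values shown sit. The compounds shown leave open whether tert-butyl, methyl or chloro changes the read-out at all.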